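Chain substitution on the core: notes toward compound 4

This account rests on a few compounds, and the source may have more. Where it says the series, first, only, none or still open, it means among the compounds named here.

Within the data shown here, the series shares the core of compound 1 `Cn1c(Cc2nn(C)c(=O)c3ccccc23)nnc1SCC(=O)Nc1ccc(Cl)cc1Cl`, which in an assay on 32D cells for inhibition of interleukin-15 (Mus musculus), read by resazurin assay, with stated times of 30 min and 2.5 days, in the presence of a further agent that is not named here (a lower number here means a stronger inhibitor, a higher number a weaker inhibitor), gives 22500 nM, the only numerical value among the three measured compounds. The values of compound 2 and compound 3 are each a limit of the assay. Compound 2 `CCOC(CCn1c(Cc2nn(C)c(=O)c3ccccc23)nnc1SCC(=O)Nc1ccc(Cl)cc1Cl)OCC` carries a 2,2-diethoxyethyl group on a saturated chain carbon bound to an aromatic nitrogen and in this assay reaches only the limit > 30000 nM. Compound 3 `Cn1nc(Cc2nnc(SCC(=O)Nc3ccc(Cl)cc3Cl)n2CCC(=O)O)c2ccccc2c1=O` carries a carboxymethyl group on a saturated chain carbon bound to an aromatic nitrogen and in this assay likewise sits at the limit > 30000 nM. The corresponding steps read an at least 1.3-fold higher number from compound 1 to compound 2 (0.12 log units; that floor lies within the scatter) and an at least 1.3-fold higher number from compound 1 to compound 3 (0.12 log units; that floor lies within the scatter); between compound 2 and compound 3 the two limits leave the step unreadable (a step that the two limits leave unreadable from compound 2 to compound 3). Both substituted compounds thus fall at the limit of > 30000 nM in this assay, at which 2 of the 3 values shown sit.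

Compound 4 `Cn1c(Cc2nn(CCC=O)c(=O)c3ccccc23)nnc1SCC(=O)Nc1ccc(Cl)cc1Cl` is not yet measured. It differs from compound 1 as follows: formylmethyl in place of hydrogen on a saturated chain carbon bound to an aromatic nitrogen. The steps from compound 1 to compound 2 and from compound 1 to compound 3 bear on this change; both also add a chain group on a saturated chain carbon bound to an aromatic nitrogen, and both were read as modestly higher numbers whose floors lie inside the scatter. A step toward a higher number in this assay is therefore expected, or none beyond the scatter, with a real chance that only a limit is reported. Compound 4 is expected at 30000 nM, between 15000 nM and 60000 nM. The expected step is a 1.3-fold higher number from compound 1 to compound 4 (0.12 log units; within the scatter).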

Compound 4, half-maximal inhibitory concentration: 30000 nM
Compound 4: the middle estimate sits on the measured number at the digits printed, and the stated range covers the measured number.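

In this assay the formylmethyl addition sits on a different aromatic nitrogen of the shared core from the chain additions of compound 2 and compound 3, and the step reads a 1.3-fold higher number from compound 1 to compound 4 (0.12 log units; within the scatter). This is the only chain addition among the compounds shown that gives a number rather than a limit, and at this position it produces no change beyond the scatter. The other two chain additions end at limits of the assay, and limits remain common in this small set: the limit of > 30000 nM in this assay, at which 2 of the 4 values shown sit.

The limits leave the steps from compound 4 to compound 2 and to compound 3 unreadable, and those compounds also differ from compound 4 in more than one place, so the two nitrogen positions cannot be ranked against each other. Also open, as far as these compounds go, is whether a 2-aminoethyl group, a carboxylic acid or a longer chain on the nitrogen bearing the 2-formylethyl chain would give a step beyond the scatter in either direction in this assay.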